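Hydroxypropyl in place of cyclopentyl on the amine nitrogen

This account rests on a few compounds, and the source may have more. Where it says the series, first, only, none or still open, it means among the compounds named here.

For the measured compounds named here, compound 3 `Clc1ccccc1Cn1nnc2c(NC3CCCC3)nc(-c3ccccc3)nc21` gives 9000000 nM in an assay on isolated protein for binding affinity to adenosine receptor A1 (Bos taurus) (on this read-out lower numbers stand for stronger inhibition and higher numbers for weaker inhibition), and stands lowest of the three numbers measured so far. Compound 1 `Clc1ccccc1Cn1nnc2c(NC3CCC3)nc(-c3ccccc3)nc21` gives 24000000 nM, and compound 2 `CC(O)CNc1nc(-c2ccccc2)nc2c1nnn2Cc1ccccc1Cl` gives 32000000 nM. Among the measured steps there is a 2.7-fold lower number from compound 1 to compound 3 (0.43 log units; beyond the scatter) and there is a 3.6-fold lower number from compound 2 to compound 3 (0.55 log units; beyond the scatter), while there is only a 1.3-fold higher number from compound 1 to compound 2 (0.12 log units; within the scatter). Compound 4 `OCCCNc1nc(-c2ccccc2)nc2c1nnn2Cc1ccccc1Cl` differs from compound 3 in that (3-hydroxypropyl in place of cyclopentyl on a nitrogen on an aromatic ring). The step that bears on this is the one in which cyclopentyl replaced 2-hydroxypropyl, here run in reverse with 3-hydroxypropyl entering; a modest rise in the number is therefore expected, a 3.3-fold higher number from compound 3 to compound 4 (0.52 log units; beyond the scatter). Compound 4 is estimated at 30000000 nM, with a range of 12000000 nM to 80000000 nM.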

Compound 4, inhibition constant: 33000000 nM
Estimate against measurement, compound 4: 1.1-fold (0.04 log units) below; the measured number falls inside the stated range.
By their numbers in this assay, from the lowest: compound 3; then compounds 1, 2 and 4 (each within the scatter of the next).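

In this assay, the place of the hydroxyl on the chain makes no readable difference (a 1.0-fold higher number from compound 2 to compound 4 (0.01 log units; within the scatter)), and the cyclobutyl compound also stays within the scatter of 3-hydroxypropyl (a 1.4-fold higher number from compound 1 to compound 4 (0.14 log units; within the scatter)). Only cyclopentyl stands apart on this nitrogen (a 3.7-fold higher number from compound 3 to compound 4 (0.56 log units; beyond the scatter)), so the hydroxypropyl isomers and cyclobutyl form one group here. Nothing available accounts for this separation.

Still open, as far as these compounds go, is whether an amine or a carboxylic acid at the chain end, or a longer chain bearing the hydroxyl, would shift the number. Also open, from the compounds shown here alone, is how a cyclohexyl group would compare with cyclopentyl.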